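The compounds below may be only part of what the source reports. "The series", "measured", "known", "first", "only" and "open" are said of these compounds alone.

Compound 3 `CC(C)[C@@H]1CC[C@@H](C)C[C@@]12N(C)C(=O)[C@@H]1[C@H]3C(=O)N(c4ccc(Cl)cc4)C(=O)[C@H]3ON12` is the strongest of the three measured compounds in a functional assay, read by spectrophotometry, with a stated time of 2 h, tested at 0.5 mg/mL; a higher number here means a stronger effect of the compound at the concentration tested, a lower number a weaker effect: in this assay compound 3 gives 47.5%. Compound 1 `CC(C)[C@@H]1CC[C@@H](C)C[C@@]12N(C)C(=O)[C@@H]1[C@H]3C(=O)NC(=O)[C@H]3ON12` gives 25.9%, and compound 2 `CC(C)[C@@H]1CC[C@@H](C)C[C@@]12N(C)C(=O)[C@@H]1[C@H]3C(=O)N(c4ccccc4)C(=O)[C@H]3ON12` gives 28.7%; these two lie within the scatter of each other, as a number 2.8 percentage points higher from compound 1 to compound 2 (within the scatter) shows. The larger steps are the ones that bring in the chloro group: a number 18.8 percentage points higher from compound 2 to compound 3 (beyond the scatter) and a number 21.6 percentage points higher from compound 1 to compound 3 (beyond the scatter).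

Compound 4 `Cc1cccc(N2C(=O)[C@H]3[C@H](ON4[C@@H]3C(=O)N(C)[C@@]43C[C@H](C)CC[C@H]3C(C)C)C2=O)c1` differs from compound 3 in a single place: 3-methylphenyl in place of 4-chlorophenyl on an amide-type nitrogen in a ring. Among the compounds with values here, no measured step introduces a methyl group on the aromatic ring, so the only guidance is the step of a number 18.8 percentage points higher from compound 2 to compound 3 (beyond the scatter), which compound 4 undoes by removing the chloro group, and the step of a number 2.8 percentage points higher from compound 1 to compound 2 (within the scatter), which shows that a phenyl ring without a substituent changes the number by little. One therefore expects the number to fall back toward that of compound 2, by a modest step in this assay, a number 14.5 percentage points lower from compound 3 to compound 4 (beyond the scatter), with the methyl group left as an unknown that could shift the result either way. For compound 4 the estimate in this assay is 33%, with a range from 22% to 46%.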

Compound 4, a percentage reported as activity, at one concentration (the size of the read-out at that concentration, not a potency): 25%
Estimate against measurement, compound 4: 8 percentage points above; the measured number falls inside the stated range.
By their numbers in this assay, from the lowest: compounds 4, 1 and 2 (each within the scatter of the next); then compound 3.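

In this assay, the change from 4-chlorophenyl to 3-methylphenyl on the amide-type nitrogen gives a number 22.5 percentage points lower from compound 3 to compound 4 (beyond the scatter), so the higher number of compound 3 does not extend to this other substituted phenyl ring. Adding a methyl group to the phenyl ring gives a number 3.7 percentage points lower from compound 2 to compound 4 (within the scatter), and 3-methylphenyl in place of hydrogen on the nitrogen gives a number 0.9 percentage points lower from compound 1 to compound 4 (within the scatter); at this position, therefore, neither a phenyl ring nor this methylated one separates from the unsubstituted nitrogen, and among the four compounds only the 4-chlorophenyl group stands apart. Nothing shown here gives a measured reason for this difference.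

The step between compound 3 and compound 4 changes both the group and its place on the ring, so the compounds shown do not settle whether the higher number follows the chloro group itself or its ring position. A 3-chlorophenyl and a 4-methylphenyl group would separate these two changes, while 4-bromophenyl or 4-methoxyphenyl groups would show whether other groups at that ring position behave like chloro.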